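Methylsulfonyl on the Amine of Compound 3

A few compounds are considered here, and "the series" means these few. Any claim that something is new, unique, unknown or untested is made for them only; others in the source may bear on it.

Compound 1 `O/N=C(\Nc1ccc(F)c(Br)c1)c1nonc1NCc1ccccc1`: < 0.005
Compound 2 `COCCNc1nonc1/C(=N/O)Nc1ccc(F)c(Br)c1`: 0.009
Compound 3 `NCCNc1nonc1/C(=N/O)Nc1ccc(F)c(Br)c1`: 0.061
Compound 4 `CS(=O)(=O)NCCNc1nonc1/C(=N/O)Nc1ccc(F)c(Br)c1`: not yet measured

In an ADME assay on a cell-free system (plasma, Homo sapiens) for protein binding, using equilibrium dialysis, with a stated time of 2 h (a lower number here means a smaller unbound share, a higher number a larger unbound share of the compound), compound 3 has the highest number of the three measured compounds at 0.061, while compound 2 follows at 0.009. The entry for compound 1, < 0.005, is a limit of the assay and not a number.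

Compound 4 carries methylsulfonyl in place of hydrogen on an amine nitrogen. Among the measured compounds shown here, three measured steps bear on this change. Methoxymethyl in place of phenyl gave an at least 1.8-fold higher number from compound 1 to compound 2 (0.25 log units; that floor lies within the scatter). Aminomethyl in place of phenyl gave an at least 12-fold higher number from compound 1 to compound 3 (1.08 log units; beyond the scatter), and amino in place of methoxy gave a 6.8-fold higher number from compound 2 to compound 3 (0.83 log units; beyond the scatter). The two steps beyond the scatter both lead to compound 3, and in compound 4 that amino becomes methanesulfonamido. For the measured compounds named here, no measured step involves methylsulfonyl, so the expectation rests on analogy alone: a modest move to a lower number, beyond the scatter. The expected change is a 4.1-fold lower number from compound 3 to compound 4 (0.61 log units; beyond the scatter). For compound 4 the estimated value is 0.015, with an expected range from 0.006 to 0.04.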

Compound 4, unbound fraction: 0.024
Estimate against measurement, compound 4: 1.6-fold (0.20 log units) below, and the stated range covers the measured number.
By their numbers in this assay, from the lowest: compound 2; then compound 4; then compound 3. At a limit, below all of these: compound 1.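

In this assay, among the compounds shown here, methylsulfonyl in place of hydrogen on the amine nitrogen gave a 2.5-fold lower number from compound 3 to compound 4 (0.41 log units; beyond the scatter), so the free amine of compound 3 is not the only end group on this chain that holds the number above that of compound 2. Methanesulfonamido in place of methoxy gave a 2.7-fold higher number from compound 2 to compound 4 (0.43 log units; beyond the scatter), which sets compound 4 apart from both neighbours, with each gap beyond the scatter. Compound 1 stands at a limit and not a number, so the comparison with its phenyl, an at least 4.8-fold higher number from compound 1 to compound 4 (0.68 log units; beyond the scatter), gives only a floor: the limit of < 0.005 in this assay, at which 1 of the 4 values shown sits.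

The compounds shown leave open how far this trend holds for other groups on the same amine nitrogen, such as acetyl or a second methyl. They also leave open what a carboxylic acid at the chain end, or a longer chain carrying methanesulfonamido, would give.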